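Sulfamoylphenyl for Chlorophenyl on the Sulfinyl Amide Side Chain

A few compounds are considered here, and "the series" means these few. Any claim that something is new, unique, unknown or untested is made for them only; others in the source may bear on it.

Measured compounds:
compound 1, `COc1cc2nc(Nc3ccc(C#N)cc3)nc(Nc3c(C)cc(/C=C/C#N)cc3C)c2cc1OC`, 10200 nM
compound 2, `COc1cc2nc(SCC(=O)Nc3ccc(C#N)cc3)nc(Nc3c(C)cc(/C=C/C#N)cc3C)c2cc1OC`, > 227000 nM
compound 3, `COc1cc2nc([S+]([O-])CC(=O)Nc3ccc(Cl)cc3)nc(Nc3c(Cl)cc(/C=C/C#N)cc3Cl)c2cc1OC`, 14400 nM

Three compounds sharing one core were tested in an ADME assay on MT4 cells (Homo sapiens) for cytotoxicity, read by MTT assay, with a stated time of 5 days; a lower number here means that less compound is tolerated, a higher number that more compound is tolerated. Compound 1, `COc1cc2nc(Nc3ccc(C#N)cc3)nc(Nc3c(C)cc(/C=C/C#N)cc3C)c2cc1OC`, gives 10200 nM. For compound 2, `COc1cc2nc(SCC(=O)Nc3ccc(C#N)cc3)nc(Nc3c(C)cc(/C=C/C#N)cc3C)c2cc1OC`, the result is a limit of the assay, > 227000 nM, and not a number (the limit of > 227000 nM in this assay, at which 1 of the 3 values shown sits). Compound 3, `COc1cc2nc([S+]([O-])CC(=O)Nc3ccc(Cl)cc3)nc(Nc3c(Cl)cc(/C=C/C#N)cc3Cl)c2cc1OC`, gives 14400 nM, the highest of the two numbers; compound 1 sits within the scatter of it, so the two cannot be ordered.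

The piece now turns to compound 4, `COc1cc2nc([S+]([O-])CC(=O)Nc3cccc(S(N)(=O)=O)c3)nc(Nc3c(Cl)cc(/C=C/C#N)cc3Cl)c2cc1OC`, which has not been measured in this assay . Against compound 3 the change is 3-sulfamoylphenyl in place of 4-chlorophenyl on an amide-type nitrogen. Within the data shown here, no step between two measured compounds touches this position, so the size of the step is open. Since compound 2 reached only a limit of the assay in this assay , a move toward greater tolerance is plausible but not established by a measured step. The author expects the step of a 2.8-fold higher number from compound 3 to compound 4 (0.44 log units; beyond the scatter) to be modest, toward a higher number. Compound 4 is estimated at 40000 nM, with a range from 12000 nM to 150000 nM.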

Compound 4, half-maximal cytotoxic concentration: 67800 nM
Compound 4: middle estimate off by 1.7-fold (0.23 log units), on the low side; low and high end bracket the measured number.
By their numbers in this assay, from the lowest: compounds 1 and 3 (each within the scatter of the next); then compound 4. At a limit, above all of these: compound 2.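

In this assay, the aryl group on the amide-type nitrogen of the sulfinyl side chain now has a measured effect: 3-sulfamoylphenyl in place of 4-chlorophenyl gives a 4.7-fold higher number from compound 3 to compound 4 (0.67 log units; beyond the scatter), a step beyond the scatter. Among these compounds, the earlier compounds offered no step between measured compounds at this or any other position, so this is the first size that can be put on a single change. It is also a clean reading, as the shared core, the sulfinyl link and the two chlorines of the aniline ring stay the same in both compounds, though nothing measured here on the two groups speaks to why the number moves.

On these data alone, compound 4 loses the chlorine and gains the sulfamoyl group in one exchange, so how the step divides between the two stays open. Also open, as far as these compounds go, is how a plain phenyl, or a phenyl carrying a carboxylic acid or an amine, would stand on the same side chain, and whether the step would keep its size and direction with those groups.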